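A Bromo Analogue in a Series Without Measurable Cytotoxicity

The source may hold more compounds than are shown below. What is called first, only, known or untested is meant among the compounds shown, and "the series" means these compounds.

Compound 1, `C/C(=N\NC(=O)c1ccncc1)C(=O)Nc1ccc(C(F)(F)F)cc1`: > 50000 nM
Compound 2, `C/C(=N\NC(=O)c1ccncc1)C(=O)Nc1ccc(Cl)cc1`: > 50000 nM
Compound 3, `C/C(=N\NC(=O)c1ccncc1)C(=O)Nc1cc(Cl)cc(Cl)c1`: > 50000 nM

In a functional assay on HepG2 cells (Homo sapiens) for cytotoxicity, read by MTT assay, with a stated time of 72 h (on this read-out higher numbers stand for weaker inhibition and lower numbers for stronger inhibition), compound 1 reaches only a limit of the assay, > 50000 nM, and no number is known for it. Compound 2 likewise reaches only a limit, > 50000 nM. Compound 3 also reaches only a limit, > 50000 nM. Going by the values given here, the one measured step that changes a single place, a step that the two limits leave unreadable from compound 1 to compound 2, is therefore unreadable, and the evidence for the whole set is the limit of > 50000 nM in this assay, at which 3 of the 3 values shown sit.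

The compound not yet measured is compound 4, `C/C(=N\NC(=O)c1ccncc1)C(=O)Nc1ccc(Br)cc1`. It differs from compound 1 by bromo in place of trifluoromethyl on an aromatic carbon. No readable step bears on this change; the nearest comparison is compound 2, which sits at its limit with bromo's neighbour chloro at the same place. The expected step that the limit leaves unreadable from compound 1 to compound 4 is thus none that can be read against a limit. Compound 4 is estimated at 80000 nM in this assay, within 30000 nM to 300000 nM, and most likely it too would be reported only as a limit.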

Compound 4, half-maximal inhibitory concentration: > 50000 nM
Compound 4 was reported as a limit; the forecaster's own chance of this, stated with the estimate: 85%; the middle value is on the limit's open side.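

In this assay compound 4 gives > 50000 nM, which is a limit and not a number. Going by these compounds alone, no new step can therefore be read from compound 4 to compound 1 or compound 2: the limit of > 50000 nM in this assay, at which 4 of the 4 values shown sit. The compounds shown leave open how bromo, chloro and trifluoromethyl compare at this place.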